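Adding a Second Chloro to a Purine-Type Core

The source may report more compounds than this note shows. Statements on the series, on what has been measured and on what is new or still open speak of the compounds shown alone.

Compound 1, `ClCc1ccc(Cn2cnc3c(Cl)ncnc32)cc1`: in a functional assay on HT-29 cells (Homo sapiens) for cytotoxicity, read by sulforhodamine B assay, with a stated time of 48 h (on this read-out higher numbers stand for weaker inhibition of growth and lower numbers for stronger inhibition of growth), compound 1 is recorded as "not determined" (no result reported).
Compound 2, `ClCc1ccccc1Cn1cnc2ncnc(Cl)c21`: in this assay compound 2 gives 3890 nM.

Compound 1 therefore has no number of its own here; the only point of reference is compound 2, a close relative, which sits at the weaker end of the growth-inhibition scale. Compound 3, `ClCc1ccc(Cn2cnc3c(Cl)nc(Cl)nc32)cc1`, differs from compound 1 by chloro in place of hydrogen on an aromatic carbon. Going by the values given here, with no measured pair to lean on, no step beyond the usual scatter is expected in either direction. For compound 3 the expected value is 3500 nM, with a plausible range from 600 nM to 20000 nM.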

Compound 3, concentration for 50% growth inhibition: 2880 nM
Beside the measured number, compound 3's estimate is 1.2-fold (0.08 log units) above it; measured number inside the range.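

Compound 1 has no number to set against compound 3, so no step can be read from this pair. Going by these compounds, whether chloro in place of hydrogen on the shared core changes growth inhibition stays open. No other data here bear on this result.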